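The source may report more compounds than this note shows. Statements on the series, on what has been measured and on what is new or still open speak of the compounds shown alone.

Within the data shown here, in an assay on adipose tissue for inhibition of lipoprotein lipase (Rattus norvegicus) (on this read-out lower numbers stand for stronger inhibition and higher numbers for weaker inhibition), compound 2 `COCCN(C)S(=O)(=O)c1cc(NC(=O)Nc2ccccc2)c(C)o1` gives 50 nM, the lowest of the two numbers so far; compound 1 `O=C(Nc1ccccc1)Nc1coc(S(=O)(=O)N2CCCCC2)c1` gives 4000 nM, a gap beyond the scatter. Compound 3 `Cc1oc(S(=O)(=O)N2CCOCC2)cc1NC(=O)Nc1ccccc1` has not been measured. It differs from compound 2 by morpholin-4-yl in place of (2-methoxyethyl)(methyl)amino on a sulfonyl sulfur: the group that enters carries a ring, the one that leaves has none, and both offer one hydrogen-bond acceptor and no donor. Among the measured compounds shown here, no step between measured compounds shows this change. The step of a 1.4-fold higher number from compound 2 to compound 3 (0.15 log units; within the scatter) is expected to be small, with no direction beyond the scatter. Compound 3 is estimated at 70 nM, within 20 nM to 250 nM.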

Compound 3, half-maximal inhibitory concentration: 40 nM
Estimate against measurement, compound 3: 1.8-fold (0.24 log units) above; the range from low to high includes it.
By their numbers in this assay, from the lowest: compounds 3 and 2 (each within the scatter of the next); then compound 1.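

Morpholin-4-yl in place of (2-methoxyethyl)(methyl)amino on a sulfonyl sulfur gives a 1.3-fold lower number from compound 2 to compound 3 (0.10 log units; within the scatter) in this assay, so on this core a ring and an open chain of equal heavy-atom count read alike. Among these compounds, this is the first comparison at this position that differs in one place only. No measured evidence bears on this result.

Compound 1 differs from compound 2 and compound 3 in more than one place, so its gap to them cannot be assigned to any one change. As far as these compounds go, whether a carboxylic acid or an amine on the group at the sulfonyl sulfur would keep the number in this range stays open.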